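Alkylidene butenolides: exocyclic double-bond geometry and cytotoxicity

The compounds below may be only part of what the source reports. "The series", "measured", "known", "first", "only" and "open" are said of these compounds alone.

Two butenolide-bearing terpenoids have so far been measured in a functional assay on SK-OV-3 cells (Homo sapiens) for cytotoxicity; a lower number here means that less compound is needed, a higher number that more compound is needed for the effect. Compound 1 `CC1=C(O)[C@@H](C/C(C)=C\CCC(C)/C=C/C=C(\C)CCCc2ccoc2)OC1=O` carries the side chain on a saturated ring carbon and gives in this assay a value of 22.1 ug/mL. Compound 2 `CC1=C(O)/C(=C\[C@H](C)CC/C=C(/C)CCCc2coc(Cc3ccoc3)c2)OC1=O` presents the side chain through an exocyclic double bond and gives in this assay a value of 6.24 ug/mL. Of the two numbers, compound 2 stands at the lower one; the gap to compound 1 lies beyond the usual scatter of this measurement, so compound 2 is the more potent of the pair on the present data.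

Compound 3 `CC1=C(O)/C(=C/[C@H](C)CC/C=C(/C)CCCc2coc(Cc3ccoc3)c2)OC1=O` is the next candidate for this assay. Relative to compound 2: the two compounds have the same atoms and bonds and differ only in configuration as drawn: 1 of 3 stereo elements differ; a double bond is drawn E in compound 2 and Z in compound 3. For the measured compounds named here, no pair already measured isolates this kind of change, so nothing in the present numbers sets the size of the step. With the same atoms and bonds retained, the expectation is a step of modest size, if any, most likely toward a somewhat higher number, and quite possibly none beyond the scatter. The estimated step from compound 2 to compound 3 in this assay is a 1.4-fold higher number from compound 2 to compound 3 (0.16 log units; within the scatter). Compound 3 is thus expected to give in this assay about 9 ug/mL, within a range from 3.5 ug/mL to 22 ug/mL.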

Compound 3, concentration for half-maximal effect: 5.9 ug/mL
The estimate for compound 3 lay 1.5-fold (0.18 log units) above the measured number, within the range that was stated.
By their numbers in this assay, from the lowest: compounds 3 and 2 (each within the scatter of the next); then compound 1.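

For the compounds shown here, compounds 2 and 3 form the first pair that isolates the geometry of the exocyclic double bond, and in this assay the result is a 1.1-fold lower number from compound 2 to compound 3 (0.02 log units; within the scatter), so exchanging E for Z at this bond gives no separation that can be told from the scatter. This reading concerns that one stereo element alone, with the side chain and the rest of the shared core held constant: the fact that compounds 2 and 3 differ only in the configuration as drawn. Compound 1 differs from both compounds in more than one place, so its distance from them cannot be read as a step, though the pair does show that choosing between these two geometries does not reproduce that distance.

As far as these compounds go, whether this insensitivity to geometry would hold with a different side chain, such as a shorter chain or one ending in an amine or a carboxylic acid, remains open. Also open, from the compounds shown here alone, is which structural difference separates compound 1 from compounds 2 and 3, and what the remaining stereo elements contribute.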